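A few compounds are considered here, and "the series" means these few. Any claim that something is new, unique, unknown or untested is made for them only; others in the source may bear on it.

Compound 3, `O=C(NCc1ccc(S(=O)(=O)c2ccccc2)cc1)c1cc2ccncc2s1`, gives the lowest of the three numbers measured in an assay for inhibition of Nicotinamide phosphoribosyltransferase (Homo sapiens), read by mass spectrometry, with stated times of 15 min and 30 min (a lower number here means a stronger inhibitor, a higher number a weaker inhibitor), with 7 nM. Compound 1, `Cc1ccccc1S(=O)(=O)c1ccc(CNC(=O)c2cc3cnccc3[nH]2)cc1`, gives 12 nM in this assay, a value within the scatter of compound 3. Compound 2, `O=C(NCc1ccc(S(=O)(=O)c2ccccc2)cc1)c1nc2cnccc2[nH]1`, gives 7100 nM, and the change to compound 3 was a 1000-fold lower number from compound 2 to compound 3 (3.01 log units; beyond the scatter), a large step with the whole bicyclic group on the carbonyl carbon exchanged.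

Compound 4, `O=C(NCc1ccc(S(=O)(=O)c2ccccc2)cc1)c1cc2ncccc2s1`, differs from compound 3 only in how the same atoms are joined: a group of 9 heavy atoms (7 carbon, 1 nitrogen, 1 sulfur; one five-membered aromatic ring with 1 hetero atom, one six-membered aromatic ring with 1 hetero atom) in place of a group of 9 heavy atoms (7 carbon, 1 nitrogen, 1 sulfur; one five-membered aromatic ring with 1 hetero atom, one six-membered aromatic ring with 1 hetero atom), on a carbonyl carbon. No measured step bears directly on such a rearrangement within the bicyclic group; the one listed step, from compound 2 to compound 3, changed the atoms themselves, and compounds 1 and 3 show only that two different bicyclic groups can give values close to each other. Without a matching precedent, a step in this assay of modest size, toward a higher number, is expected, a 4.3-fold higher number from compound 3 to compound 4 (0.63 log units; beyond the scatter). Compound 4 is therefore estimated at 30 nM, within a range of 5 nM to 300 nM.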

Compound 4, half-maximal inhibitory concentration: 400 nM
For compound 4 the middle estimate is 13-fold (1.12 log units) below the measured one; measured number above the stated range.
By their numbers in this assay, from the lowest: compounds 3 and 1 (each within the scatter of the next); then compound 4; then compound 2.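

In this assay, the arrangement of the same atoms within the bicyclic group on the carbonyl carbon proves to matter by itself: with atom counts, ring types and hydrogen-bond counts unchanged, the rearrangement gives a 57-fold higher number from compound 3 to compound 4 (1.76 log units; beyond the scatter) and so composition alone does not set the number at this place. The group of compound 4 still compares well with the group of compound 2, as shown by an 18-fold lower number from compound 2 to compound 4 (1.25 log units; beyond the scatter) even though it has lost much of what compound 3 gained. Nothing measured here accounts for the difference between the two arrangements.

As far as these compounds go, whether an amine or a carboxylic acid on the six-membered aromatic ring of this group would shift the number remains open. So does whether a similar rearrangement within the bicyclic group of compound 1 would bring a step of like size.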